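Ring Size Swap on a Compound Already at the Limit

The source may report more compounds than this note shows. Statements on the series, on what has been measured and on what is new or still open speak of the compounds shown alone.

The four compounds share one core and differ in two places. Compound 1 `O=C(CN1CCCC1)Nc1ccc2ncnc(Nc3ccc(Cl)cc3)c2c1` carries a 4-chlorophenyl group and a pyrrolidin-1-yl ring. In a functional assay on HepG2 cells (Homo sapiens) for antiproliferative activity, read by MTT assay, with a stated time of 48 h (a lower number here means a stronger inhibitor, a higher number a weaker inhibitor), compound 1 gives 18000 nM. Compound 2 `O=C(CN1CCCCC1)Nc1ccc2ncnc(Nc3ccc(Cl)cc3)c2c1` differs from compound 1 in one place: piperidin-1-yl in place of pyrrolidin-1-yl on a saturated chain carbon bound to a carbonyl carbon. In this assay compound 2 gives 16000 nM. That change produced a step of a 1.1-fold lower number from compound 1 to compound 2 (0.05 log units; within the scatter).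

Compound 3 `O=C(CN1CCCC1)Nc1ccc2ncnc(Nc3cccc(Br)c3)c2c1` differs from compound 1 in the other place: 3-bromophenyl in place of 4-chlorophenyl on a nitrogen on an aromatic ring. For compound 3 this assay reports only a limit rather than a number, > 100000 nM, which is the limit of > 100000 nM in this assay, at which 1 of the 3 values shown sits. The step from compound 1 to compound 3 was an at least 5.5-fold higher number from compound 1 to compound 3 (0.74 log units; beyond the scatter).

Compound 4 `O=C(CN1CCCCC1)Nc1ccc2ncnc(Nc3cccc(Br)c3)c2c1` has not yet been measured. It differs from compound 3 as piperidin-1-yl in place of pyrrolidin-1-yl on a saturated chain carbon bound to a carbonyl carbon, the same change that turned compound 1 into compound 2, at the same place. The expected step for compound 4 is a number no higher from compound 3 to compound 4 (the limit leaves the size open), because the same change gave a 1.1-fold lower number from compound 1 to compound 2 (0.05 log units; within the scatter) and that step lay within the scatter. Compound 4 is therefore expected to give about 100000 nM, with a range from 40000 nM to 300000 nM. Because compound 3 itself gave > 100000 nM, the result for compound 4 is expected most likely to come back as a limit as well rather than a number.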

Compound 4, half-maximal inhibitory concentration: 16000 nM
The estimate for compound 4 lay 6.3-fold (0.80 log units) above the measured number, outside the stated range (below it).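

In this assay, piperidin-1-yl in place of pyrrolidin-1-yl gave an at least 6.2-fold lower number from compound 3 to compound 4 (0.79 log units; beyond the scatter), so the change did not carry over from the core of compound 1 to the core of compound 3 at the same size: the same change on two cores in this assay, a 1.1-fold lower number (0.05 log units; within the scatter) from compound 1 to compound 2 and an at least 6.2-fold lower number (0.79 log units; beyond the scatter) from compound 3 to compound 4, at least 5.5-fold (0.74 log units) apart, beyond the scatter of two such steps

Seen from the other direction, 3-bromophenyl in place of 4-chlorophenyl gave no change at the digits printed from compound 2 to compound 4 (within the scatter), so this swap also gave different results with the two rings: the same change on two cores in this assay, an at least 5.5-fold higher number (0.74 log units; beyond the scatter) from compound 1 to compound 3 and no change at the digits printed (within the scatter) from compound 2 to compound 4, at least 5.5-fold (0.74 log units) apart, beyond the scatter of two such steps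

This shows that, in these four compounds, the effect of a change in one place depends on what sits in the other place, but it does not show why, and compound 3 stands only at a limit, which leaves the true size of its step to compound 4 unknown: the limit of > 100000 nM in this assay, at which 1 of the 4 values shown sits.

The compounds shown leave open whether the same dependence appears with another ring, such as morpholin-4-yl, or with a longer chain in the same place. They also leave open whether it follows the halogen or its position, which 3-chlorophenyl and 4-bromophenyl groups on the otherwise same compounds could help separate.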